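The compounds below may be only part of what the source reports. "The series", "measured", "known", "first", "only" and "open" are said of these compounds alone.

Measured compounds:
compound 1, `C/C(=C1/OC(=O)NC1=O)C(c1ccc(-c2ccc3cccc(F)c3c2)[nH]c1=O)C(C)C`: 39 nM
compound 2, `CCC(CC)C(/C=C1\OC(=O)NC1=O)c1ccc(-c2ccc3cccc(F)c3c2)[nH]c1=O`: 23 nM
compound 3, `CC(C)[C@H](C[C@@H]1OC(=O)NC1=O)c1ccc(-c2ccc3cccc(F)c3c2)[nH]c1=O`: 27 nM

In a functional assay on CHO cells for antagonist activity at prostaglandin E2 receptor EP3 subtype (Homo sapiens), read by cAMP accumulation, with a stated time of 30 min (on this read-out lower numbers stand for stronger inhibition and higher numbers for weaker inhibition), compound 1 gives 39 nM, the highest of the three numbers. Compound 3 is nearest to it, and compound 2 furthest, yet both gaps sit within the usual scatter of repeated measurements, so nothing separates the three compounds on this read-out. Within the data shown here, no single-point step between measured compounds is available to guide the next move.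

Compound 4, `CC(C)C(CC1C(=O)NC(=O)N1C)c1ccc(-c2ccc3cccc(F)c3c2)[nH]c1=O`, is not yet measured. It departs from compound 1 by the change (a group of 9 heavy atoms (5 carbon, 2 nitrogen, 2 oxygen; one five-membered non-aromatic ring with 2 hetero atoms) in place of a group of 9 heavy atoms (5 carbon, 1 nitrogen, 3 oxygen; one five-membered non-aromatic ring with 2 hetero atoms), on a saturated chain carbon bound to an aromatic carbon and a saturated chain carbon). The group that leaves carries its ring on a double bond, whereas the (3-methyl-2,5-dioxoimidazolidin-4-yl)methyl group that enters is attached through a saturated link, as in compound 3, whose value 27 nM lies close to that of compound 1.

Compound 4 is therefore expected to stay near compound 1, with a step of a 1.5-fold higher number from compound 1 to compound 4 (0.19 log units; within the scatter) that may fall within the scatter or drift slightly toward weaker inhibition. The estimate for compound 4 in this assay is 60 nM, within a range from 20 nM to 200 nM.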

Compound 4, half-maximal inhibitory concentration: 65 nM
Estimate against measurement, compound 4: 1.1-fold (0.03 log units) below; low and high end bracket the measured number.
By their numbers in this assay, from the lowest: compounds 2, 3, 1 and 4 (each within the scatter of the next, the first and the last beyond it).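

In this assay the step of a 1.7-fold higher number from compound 1 to compound 4 (0.22 log units; within the scatter) shows that, on this saturated chain carbon, the (3-methyl-2,5-dioxoimidazolidin-4-yl)methyl group can take the place of the group in compound 1 without a difference that clears the scatter. The exchange keeps the heavy-atom count and the single hydrogen-bond donor, yet goes from 3 hydrogen-bond acceptors to 2 and from 3 double bonds outside aromatic rings to 2, and the read-out does not separate the two compounds. No measurement at hand bears on why they read alike.

The compounds shown leave open how a carboxylic acid or an amine would read on this carbon. They also leave open how much of the step belongs to the new ring and how much to the loss of the double bond, as both arrive in this one change.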